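Aryl swap on the isoxazole of the shared core

A few compounds are considered here, and "the series" means these few. Any claim that something is new, unique, unknown or untested is made for them only; others in the source may bear on it.

Measured so far:
compound 1 `COc1ccc2nc(N(Cc3cc(-c4ccc(OC(F)(F)F)cc4)no3)c3nc4ccc(F)cc4s3)sc2c1` — 23100 nM
compound 2 `COc1ccc2nc(N(Cc3cc(-c4ccc(Br)cc4)no3)c3nc4ccc(F)cc4s3)sc2c1` — 34900 nM

In a functional assay on U-937 cells (Homo sapiens) for antiproliferative activity, read by MTT assay (on this read-out higher numbers stand for weaker inhibition and lower numbers for stronger inhibition), compound 1 gives 23100 nM and compound 2 gives 34900 nM. Within the data shown here, compound 1 holds the lowest of the two numbers, but its nearest neighbour is compound 2, and the only measured step, a 1.5-fold higher number from compound 1 to compound 2 (0.18 log units; within the scatter), lies within the scatter; the two compounds cannot be ordered on this assay.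

Compound 3 `COc1ccc2nc(N(Cc3cc(-c4ccccc4F)no3)c3nc4ccc(F)cc4s3)sc2c1` is not yet measured. It differs from compound 1 in one place: 2-fluorophenyl in place of 4-(trifluoromethoxy)phenyl on an aromatic carbon.

Among the measured compounds shown here, the single step that bears on this change is the one from compound 1 to compound 2, in which another group on the same phenyl ring was exchanged and the number moved a 1.5-fold higher number from compound 1 to compound 2 (0.18 log units; within the scatter), within the scatter. For the measured compounds named here, no measured pair tells how the shared core responds to a phenyl carrying only fluorine, or to a group placed as in the 2-fluorophenyl. On that basis no step beyond the scatter is expected for compound 3 in this assay, with a wide range to either side.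

For compound 3 the estimate is 30000 nM, expected between 11000 nM and 85000 nM, a step of a 1.3-fold higher number from compound 1 to compound 3 (0.11 log units; within the scatter) from compound 1.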

Compound 3, half-maximal inhibitory concentration: 29500 nM
Compound 3: the middle estimate sits 1.0-fold (0.01 log units) above what was measured; the measured number falls inside the stated range.
By their numbers in this assay, from the lowest: compounds 1, 3 and 2 (each within the scatter of the next).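

In this assay, the step to 2-fluorophenyl gives a 1.3-fold higher number from compound 1 to compound 3 (0.11 log units; within the scatter), and the corresponding step from 4-bromophenyl gives a 1.2-fold lower number from compound 2 to compound 3 (0.07 log units; within the scatter), so compound 3 cannot be ordered against either earlier compound. On the aromatic carbon of the five-membered aromatic ring with 1 nitrogen and 1 oxygen, the three substituted phenyl groups shown therefore remain unseparated, even though the change from 4-(trifluoromethoxy)phenyl to 2-fluorophenyl goes from 11 heavy atoms to 7 and from 1 hydrogen-bond acceptor to 0. Nothing available explains why the numbers stay within the scatter of one another.

Every compound shown carries a halogen-containing phenyl group at this position on an otherwise unchanged shared core, so it remains open whether an aminomethyl or carboxylic acid group on that phenyl ring, or a longer alkyl chain in its place, would give a step beyond the scatter. From the compounds shown here alone, it also remains open whether any change elsewhere on the shared core would move the number in this assay, or whether the lack of separation seen here would hold on another core.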